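Nitro in Place of Hydroxy: What to Expect for Compound 4

The source may hold more compounds than are shown below. What is called first, only, known or untested is meant among the compounds shown, and "the series" means these compounds.

Going by the values given here, compound 2 `Oc1cc2c(cc1OCCCN1CCN(c3ccc(F)cc3)CC1)CCC2` is one of three compounds measured so far. In a functional assay on the whole organism for inhibition, with Mus musculus as the target, at a dose of 25 mg/kg by the oral route (on this read-out lower numbers stand for less inhibition and higher numbers for more inhibition at the one dose given (going by the name of the read-out)), compound 2 gives 0%. Compound 1 `Oc1cc2c(cc1OCCCN1CCN(c3ccccc3)CC1)CCC2` gives 0% in this assay, and no change at the digits printed from compound 1 to compound 2 (within the scatter). Compound 3 `Oc1cc2c(cc1OCCCN1CCN(c3cccc(Cl)c3)CC1)CCC2` gives 29% in this assay; a number 29 percentage points higher from compound 1 to compound 3 (beyond the scatter), and likewise a number 29 percentage points higher from compound 2 to compound 3 (beyond the scatter). Compound 2 thus stands level with compound 1, the two together being the lowest of the three numbers, with compound 3 the furthest from it.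

Compound 4 `O=[N+]([O-])c1cc2c(cc1OCCCN1CCN(c3ccc(F)cc3)CC1)CCC2` differs from compound 2 by nitro in place of hydroxy on an aromatic carbon. Each of the measured steps alters the group on the amine nitrogen in a ring and leaves the hydroxy on the core untouched, so none of them bears directly on the change at hand. Among the compounds with values here, the only steps beyond the scatter, those to compound 3, were modest, and they came from a different part of the molecule. Within the data shown here, with no measured step touching the hydroxy, the expectation rests on compound 2 alone, and the step is expected to be small, a number 10 percentage points higher from compound 2 to compound 4 (within the scatter). Compound 4 is therefore estimated at 10% in this assay, within a range from 0% to 35%.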

Compound 4, a percentage reported as inhibition, in the whole organism at one dose (the size of the read-out at that dose, not a potency): 28%
The estimate for compound 4 lay 18 percentage points below the measured number, and the stated range covers the measured number.
By their numbers in this assay, from the lowest: compounds 1 and 2 (each within the scatter of the next); then compounds 4 and 3 (each within the scatter of the next).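

The hydroxy position turns out to be a place where the read-out can respond: in this assay, nitro in place of hydroxy on an aromatic carbon gives a number 28 percentage points higher from compound 2 to compound 4 (beyond the scatter), with the 4-fluorophenyl group on the amine nitrogen left unchanged. The earlier steps had shown a response only to changes in the aryl group on that nitrogen, so this result shows that the reading of compound 2 can be moved from the core as well, and that a hydroxy at this position is not needed for a measurable reading in this series. The change swaps a group with one hydrogen-bond donor for one with none and also alters the number of heavy atoms and acceptors, but nothing available links any of these differences to the result, and no supporting measurement bears on why the number moved.

On these data alone, it remains open whether the same exchange would have a similar effect with the unsubstituted phenyl or the 3-chlorophenyl group on the amine nitrogen. Also unresolved is how a methoxy, an amine, a nitrile or a carboxylic acid at this position would compare with nitro.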